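A few compounds are considered here, and "the series" means these few. Any claim that something is new, unique, unknown or untested is made for them only; others in the source may bear on it.

Working notes on the series. In a functional assay on A-431 cells (Homo sapiens) for antiproliferative activity, read by sulforhodamine B assay, with a stated time of 72 h (on this read-out lower numbers stand for stronger inhibition and higher numbers for weaker inhibition), compound 1 (`C/C=C/C(=O)Nc1cc(Nc2nccc(-c3cn(C)c4ccccc34)n2)c(OC)cc1N(C)CCN(C)C`) gives 5790 nM. Compound 2 (`C=C(C(=O)Nc1cc(Nc2nccc(-c3cn(C)c4ccccc34)n2)c(OC)cc1N(C)CCN(C)C)C(F)(F)F`) gives 11200 nM, which lies within the scatter of compound 1, so neither of the two measured compounds stands apart. Compound 3 (`C=C(Cl)C(=O)Nc1cc(Nc2nccc(-c3cn(C)c4ccccc34)n2)c(OC)cc1N(C)CCN(C)C`) follows from compound 2 by chloro in place of trifluoromethyl on a double-bonded chain carbon bound to a carbonyl carbon. Going by the values given here, one measured step bears on this change: a 1.9-fold higher number from compound 1 to compound 2 (0.29 log units; within the scatter), with 1-(trifluoromethyl)ethenyl in place of prop-1-en-1-yl on a carbonyl carbon. Among the compounds with values here, that step stayed within the scatter, and no measured compound carries chloro, so no step beyond the scatter is expected in this assay. The estimated step is a 1.5-fold lower number from compound 2 to compound 3 (0.17 log units; within the scatter). The expected value for compound 3 is 7500 nM, with an estimated range from 3000 nM to 16000 nM.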

Compound 3, half-maximal inhibitory concentration: 1550 nM
Beside the measured number, compound 3's estimate is 4.8-fold (0.68 log units) above it, outside the stated range (below it).
By their numbers in this assay, from the lowest: compound 3; then compounds 1 and 2 (each within the scatter of the next).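

In this assay, going by these compounds alone, the substituent on a double-bonded chain carbon bound to a carbonyl carbon now makes a measurable difference: chloro in place of trifluoromethyl gives a 7.2-fold lower number from compound 2 to compound 3 (0.86 log units; beyond the scatter) and is the first step to pass beyond the scatter. Taking 1-chloroethenyl in place of prop-1-en-1-yl on a carbonyl carbon gives a 3.7-fold lower number from compound 1 to compound 3 (0.57 log units; beyond the scatter) as well, which leaves compound 3 with the lowest number of the three, while the other two remain within the scatter of each other. Nothing at hand accounts for this effect of chloro.

The compounds shown leave open whether the lower number is particular to chloro or would also appear with bromo, fluoro or a methyl group at this place. They also leave open how an unsubstituted ethenyl, with hydrogen at this place, would compare with these three compounds.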